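This account rests on a few compounds, and the source may have more. Where it says the series, first, only, none or still open, it means among the compounds named here.

Three amides of the shared core have numbers in a functional assay on the whole organism (strain Wistar) for inhibition, with Rattus norvegicus as the target, read by paw edema, with stated times of 60 min and 2 h, at a dose of 100 mg/kg by the oral route; a higher number here means more inhibition at the dose given (going by the name of the read-out), a lower number less inhibition. Compound 1 `CNC(=O)CC1CCc2cc(OC)c(OC)cc21` gives 30%. Compound 2 `CCCNC(=O)CC1CCc2cc(OC)c(OC)cc21` gives 28%. Compound 3 `COc1cc2c(cc1OC)C(CC(=O)NC(C)(C)C)CC2` gives 32%; its steps from the other two both lie within the scatter, a number 2 percentage points higher from compound 1 to compound 3 (within the scatter) and a number 4 percentage points higher from compound 2 to compound 3 (within the scatter), so no order among the three is established. Compound 4 `COc1cc2c(cc1OC)C(CC(=O)NC1CCCC1)CC2` is not yet measured; the change from compound 3 is cyclopentyl in place of tert-butyl on an amide-type nitrogen. Within the data shown here, the steps that bear on it are the other changes of the group on the amide nitrogen, each within the scatter: a number 2 percentage points lower from compound 1 to compound 2 (within the scatter), a number 2 percentage points higher from compound 1 to compound 3 (within the scatter) and a number 4 percentage points higher from compound 2 to compound 3 (within the scatter). No step beyond the scatter is therefore expected in this assay. The expected value for compound 4 is 31%, between 19% and 43%. The implied step, a number 1 percentage points lower from compound 3 to compound 4 (within the scatter), is expected to remain within the scatter.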

Compound 4, a percentage reported as inhibition, in the whole organism at one dose (the size of the read-out at that dose, not a potency): 52%
Compound 4: the middle estimate sits 21 percentage points below what was measured; measured number outside the range, above it.
By their numbers in this assay, from the lowest: compounds 2, 1 and 3 (each within the scatter of the next); then compound 4.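

In this assay the group on the amide-type nitrogen of the shared core can move the number beyond the scatter: cyclopentyl gives a number 20 percentage points higher from compound 3 to compound 4 (beyond the scatter) and a number 24 percentage points higher from compound 2 to compound 4 (beyond the scatter) and also a number 22 percentage points higher from compound 1 to compound 4 (beyond the scatter) in the same direction. Among the compounds shown, only the group with a ring stands apart, while methyl, propyl and tert-butyl remain within the scatter of one another. No measurement on hand bears on why this change has such an effect.

As far as these compounds go, whether the step belongs to five-membered rings alone remains open. Cyclopropyl, cyclohexyl or phenyl on the same nitrogen would test this, and a pentyl chain would test the open-chain side.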